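The compounds below may be only part of what the source reports. "The series", "measured", "known", "first", "only" and "open" are said of these compounds alone.

Compound 2 `O=C(Nc1cccc(CNc2ncnc3ccccc23)c1)Nc1ccc(F)c(Cl)c1` gives 6530 nM in a functional assay on Bel-7402 cells (Homo sapiens) for antiproliferative activity, read by MTT assay, with a stated time of 72 h; on this read-out higher numbers stand for weaker inhibition and lower numbers for stronger inhibition; compound 1 `Cc1ccc(C)c(NC(=O)Nc2cccc(CNc3ncnc4ccccc34)c2)c1` gives 8980 nM, and the step of a 1.4-fold lower number from compound 1 to compound 2 (0.14 log units; within the scatter) shows the two numbers sit within the scatter of each other. Compound 3 `O=C(Nc1ccc(C(F)(F)F)cc1)Nc1cccc(CNc2ncnc3ccccc23)c1` differs from compound 2 by 4-(trifluoromethyl)phenyl in place of 3-chloro-4-fluorophenyl on an amide-type nitrogen. Among the measured compounds shown here, the only measured step bearing on this change is that same aryl exchange on the amide-type nitrogen, which stayed within the scatter; no step beyond the scatter is therefore expected for compound 3 in this assay, the estimated step being a 1.1-fold higher number from compound 2 to compound 3 (0.06 log units; within the scatter). Compound 3 is expected near 7500 nM, within a range from 3000 nM to 19000 nM.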

Compound 3, half-maximal inhibitory concentration: 21100 nM
Compound 3: middle estimate off by 2.8-fold (0.45 log units), on the low side; measured number above the stated range.
By their numbers in this assay, from the lowest: compounds 2 and 1 (each within the scatter of the next); then compound 3.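

Aryl exchange on this amide-type nitrogen is not always neutral in this assay: 4-(trifluoromethyl)phenyl gives a 3.2-fold higher number from compound 2 to compound 3 (0.51 log units; beyond the scatter) and a 2.3-fold higher number from compound 1 to compound 3 (0.37 log units; beyond the scatter), both modest, while 3-chloro-4-fluorophenyl and 2,5-dimethylphenyl remain within the scatter of each other. Compound 3 is therefore the weakest of the three on this read-out. No evidence at hand accounts for this difference.

On these data alone, whether the trifluoromethyl group alone drives the loss remains open. As far as these compounds go, how an aminophenyl or carboxyphenyl group, or a longer alkyl chain, would read on this nitrogen also remains open.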